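Sulfonamide series: cytotoxicity notes ahead of compound 4

This account rests on a few compounds, and the source may have more. Where it says the series, first, only, none or still open, it means among the compounds named here.

Measured compounds:
Compound 1 `COc1ccc(Cl)cc1S(=O)(=O)Nc1ccc(-c2nc3ccccc3o2)cc1` — 75000 nM
Compound 2 `O=S(=O)(Nc1ccc2oc(-c3ccccc3)nc2c1)c1ccccc1C(F)(F)F` — 80000 nM
Compound 3 `O=S(=O)(Nc1ccc2oc(-c3ccccc3)nc2c1)c1ccccc1Cl` — 73000 nM

All three compounds were read in an ADME assay on HEK293 cells (Homo sapiens) for cytotoxicity, read by resazurin assay, with a stated time of 48 h; on this read-out lower numbers stand for higher toxicity in this test and higher numbers for lower toxicity in this test. Compound 3 gives the lowest of the three numbers, but its neighbours sit close: compound 1 is nearest with a gap within the scatter, and compound 2 is furthest, also within the scatter. Going by the values given here, the one single-point step available, a 1.1-fold lower number from compound 2 to compound 3 (0.04 log units; within the scatter), shows that swapping the group on the aromatic carbon of the sulfonyl aryl moved nothing beyond the scatter.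

Compound 4 `O=S(=O)(Nc1ccc2oc(-c3ccccc3)nc2c1)c1ccc(Cl)cc1` is not yet measured. It differs from compound 3 by 4-chlorophenyl in place of 2-chlorophenyl on a sulfonyl sulfur. Among the compounds with values here, no measured step moves a chloro around the sulfonyl aryl, so the only bearing is indirect: the step from compound 2 to compound 3 altered that same aryl and stayed within the scatter, and all three measured numbers cluster tightly. The expectation is therefore a step of a 1.0-fold higher number from compound 3 to compound 4 (0.01 log units; within the scatter), none beyond the scatter. Compound 4 is estimated at 75000 nM, with a range from 40000 nM to 140000 nM.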

Compound 4, half-maximal cytotoxic concentration: 65000 nM
For compound 4 the middle estimate is 1.2-fold (0.06 log units) above the measured one; the measured number falls inside the stated range.
By their numbers in this assay, from the lowest: compounds 4, 3, 1 and 2 (each within the scatter of the next).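

In this assay, going by these compounds alone, 4-chlorophenyl in place of 2-chlorophenyl on a sulfonyl sulfur gives the first reading of where the chloro stands on this aryl, not only of which group it carries (a 1.1-fold lower number from compound 3 to compound 4 (0.05 log units; within the scatter)). Taken with the earlier exchange of trifluoromethyl for chloro (a 1.1-fold lower number from compound 2 to compound 3 (0.04 log units; within the scatter)), both kinds of change on this aryl stay within the scatter, a statement limited to compounds 2, 3 and 4. No measurement on hand bears on why the number stays put under this change.

On these data alone, whether an amine or a carboxylic acid on the sulfonyl aryl would give a step beyond the scatter stays open. So does whether any change to the shared core of compounds 2, 3 and 4 would separate them in this read-out.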